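Swapping a Tetrazole for a Propionic Acid Tail

The source may report more compounds than this note shows. Statements on the series, on what has been measured and on what is new or still open speak of the compounds shown alone.

Of the compounds shown here, three built around a shared amide core have been tested in an assay on HeLa cells with Bile acid receptor (Homo sapiens) as the target, read by a luciferase reporter, with a stated time of 24 h; a lower number here means that less compound is needed, a higher number that more compound is needed for the effect. Compound 1 `CC(C)(C)c1ccc(C(=O)NCc2ccc(C(=O)O)cc2F)cc1` gives 7.8 nM. Compound 2 `CC(C)(C)c1ccc(C(=O)NCc2ccc(-c3nnn[nH]3)cc2)cc1` gives 120 nM, and compound 3 `O=C(O)c1ccc(CNC(=O)c2ccc3ccccc3c2)cc1` gives 1360 nM. Among these three numbers compound 2 stands second highest: compound 3 sits well above it, beyond the scatter, while compound 1 sits well below it, also beyond the scatter. No pair of these compounds differs in only one place, so no single-change step can be read off directly.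

Compound 4 `CC(C)(C)c1ccc(C(=O)NCc2ccc(CCC(=O)O)cc2)cc1` differs from compound 2 at one position: 2-carboxyethyl in place of 1H-tetrazol-5-yl on an aromatic carbon. The ring that carried the 1H-tetrazol-5-yl now carries a 2-carboxyethyl group instead, at the same aromatic carbon, para to a large group.

Among the measured compounds shown here, with no measured step of this kind to lean on, the expectation rests on the spread already seen. Compound 1, which lacks the tetrazole, gives the lowest number of the set with 7.8 nM, which makes a modest downward step plausible. The estimated step is a 2.0-fold lower number from compound 2 to compound 4 (0.30 log units; within the scatter), and the direction is uncertain enough that no change beyond the scatter would not surprise. Compound 4 is expected to give about 60 nM, with a likely range from 15 nM to 400 nM.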

Compound 4, half-maximal effective concentration: 350 nM
Estimate against measurement, compound 4: 5.8-fold (0.77 log units) below, within the range that was stated.
By their numbers in this assay, from the lowest: compound 1; then compound 2; then compound 4; then compound 3.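

The step of a 2.9-fold higher number from compound 2 to compound 4 (0.46 log units; beyond the scatter) in this assay shows that the number responds to what sits at this aromatic carbon, para to a large group, and that the change is modest but real. The 1H-tetrazol-5-yl and the 2-carboxyethyl have the same count of 5 heavy atoms and each has 1 hydrogen-bond donor, so matching those two counts does not keep the number in place; they still differ in that one is a five-membered aromatic ring and the other is an open chain with no ring. Nothing shown here explains the direction of this step, so the result records what happened at this position and not the reason for it.

The compounds shown leave open how much the length of the chain matters, which a carboxymethyl group or a longer 3-carboxypropyl chain at the same aromatic carbon would help to separate from the presence of the carboxylic acid. On these data alone, it also remains open whether the acid end is needed at all, a question that an amine at the end of the same chain would address.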